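Fluoro substitution in an amide-linked pyridopyrimidinone series

The compounds below may be only part of what the source reports. "The series", "measured", "known", "first", "only" and "open" are said of these compounds alone.

Measured compounds:
- compound 1, `Cn1ccc2c(Oc3ccc(NC(=O)c4cc5cccnc5n(-c5ccc(Cl)cc5)c4=O)cc3)ncnc21`, in a functional assay on A549 cells (Homo sapiens) for cytotoxicity, read by MTT assay, with a stated time of 72 h (a higher number here means a weaker inhibitor, a lower number a stronger inhibitor), compound 1 gives 75500 nM
- compound 2, `Cn1ccc2c(Oc3ccc(NC(=O)c4cc5cccnc5n(-c5ccc(Cl)cc5)c4=O)cc3F)ncnc21`, in this assay compound 2 gives 55500 nM
- compound 3, `O=C(Nc1ccc(Oc2ncnc3[nH]ccc23)c(F)c1)c1cc2cccnc2n(-c2ccc(Br)cc2)c1=O`, in this assay compound 3 gives 27300 nM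

Compound 1 and compound 2 differ by fluoro in place of hydrogen on an aromatic carbon. The step is a 1.4-fold lower number from compound 1 to compound 2 (0.13 log units; within the scatter).

Compound 3 carries a different core; how its core differs from that of compound 1 is not broken down here. Among the three measured compounds compound 3 gives the lowest number in this assay, and both gaps to compound 1 and to compound 2 lie beyond the scatter, so compound 3 is the strongest inhibitor so far.

Compound 4, `O=C(Nc1ccc(Oc2ncnc3[nH]ccc23)c(F)c1)c1cc2cccnc2n(-c2ccc(Br)cc2F)c1=O`, is not yet measured. It differs from compound 3 by fluoro in place of hydrogen on an aromatic carbon. This is the same kind of change as that from compound 1 to compound 2, but not the same: there the entering fluoro sat ortho to a large group and meta to a large group, here it sits ortho to a large group and meta to a bromo group.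

Resting on the single earlier step of a 1.4-fold lower number from compound 1 to compound 2 (0.13 log units; within the scatter), which stayed within the scatter, the expected step is a 1.2-fold lower number from compound 3 to compound 4 (0.09 log units; within the scatter). Compound 4 is accordingly estimated at 22000 nM in this assay, expected to fall between 9000 nM and 50000 nM.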

Compound 4, half-maximal inhibitory concentration: 218000 nM
Beside the measured number, compound 4's estimate is 9.9-fold (1.00 log units) below it; measured number outside the range, above it.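

In this assay, fluoro in place of hydrogen on an aromatic carbon, here ortho to a large group and meta to a bromo group, gives an 8.0-fold higher number from compound 3 to compound 4 (0.90 log units; beyond the scatter). The change therefore does not carry over as a constant increment from one core to the other in this series: the same change on two cores in this assay, a 1.4-fold lower number (0.13 log units; within the scatter) from compound 1 to compound 2 and an 8.0-fold higher number (0.90 log units; beyond the scatter) from compound 3 to compound 4, 11-fold (1.04 log units) apart, beyond the scatter of two such steps. Among these compounds, only two pairs stand behind this comparison, and they differ in the core as well as in the ring that takes the fluoro, so the data do not show which of these differences sets the outcome or how the change would behave on any further core.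

Still open, as far as these compounds go, is whether the 4-bromophenyl to 4-bromo-2-fluorophenyl change keeps this size when the core of compound 3 carries other groups elsewhere. Also open, from the compounds shown here alone, is how a methoxy group or an amine at the carbon that takes the fluoro in compound 4 would read in this assay.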